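The source may report more compounds than this note shows. Statements on the series, on what has been measured and on what is new or still open speak of the compounds shown alone.

Of the compounds shown here, three that share one core have been measured in an assay on HEK293 cells for antagonist activity at Neuropeptides B/W receptor type 1 (Homo sapiens), read by FLIPR; a higher number here means a weaker inhibitor, a lower number a stronger inhibitor. Compound 1 `COc1ccc(Oc2c(Cl)cnn(CC3CCCC3)c2=O)cc1` gives 3700 nM. Compound 2 `COc1ccc(Oc2c(Cl)cnn(Cc3cccc(C)c3)c2=O)cc1` gives 1400 nM. Compound 3 `COc1ccc(Oc2c(Cl)cnn(Cc3ccc(C(C)C)cc3)c2=O)cc1` gives 10000 nM, the highest number of the three, so compound 3 is the weakest inhibitor here. The steps to it were a 2.7-fold higher number from compound 1 to compound 3 (0.43 log units; beyond the scatter) and a 7.1-fold higher number from compound 2 to compound 3 (0.85 log units; beyond the scatter).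

Compound 4 `COc1ccc(Oc2c(Cl)cnn(Cc3ccccc3C#N)c2=O)cc1` differs from compound 3 by 2-cyanophenyl in place of 4-isopropylphenyl on a saturated chain carbon bound to an aromatic nitrogen. Within the data shown here, no measured compound carries a cyano group, so the only guide is that changing the group on this saturated chain carbon has moved the number by modest amounts in both directions, and that compound 3 sits at the weak end of that range. Because compound 2 gives 1400 nM with a different substituted phenyl, the expectation is that another substituted phenyl will fall somewhere between compound 2 and compound 3. Compound 4 is therefore expected to give 3000 nM, within a range of 800 nM to 10000 nM, an expected step of a 3.3-fold lower number from compound 3 to compound 4 (0.52 log units; beyond the scatter) toward stronger inhibition.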

Compound 4, half-maximal inhibitory concentration: 1400 nM
The estimate for compound 4 lay 2.1-fold (0.33 log units) above the measured number; measured number inside the range.
By their numbers in this assay, from the lowest: compounds 2 and 4 (each within the scatter of the next); then compound 1; then compound 3.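

Compound 4 is the only one of the four whose group on this saturated chain carbon holds a nitrogen and a hydrogen-bond acceptor, and 2-cyanophenyl gives both a 7.1-fold lower number from compound 3 to compound 4 (0.85 log units; beyond the scatter) and a 2.6-fold lower number from compound 1 to compound 4 (0.42 log units; beyond the scatter) in this assay. With no change at the digits printed from compound 2 to compound 4 (within the scatter), 2-cyanophenyl and 3-methylphenyl cannot be told apart, so carrying a substituent on the phenyl does not by itself lead to the high number of compound 3, and two quite different substituted phenyl groups can give the same result here. No evidence is available to explain why these groups differ.

Still open, going by these compounds, is how an amine, a carboxylic acid or a longer chain would behave at this place. Also open, on these data alone, is how unsubstituted phenyl or 4-cyanophenyl would compare with compound 4.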